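This account rests on a few compounds, and the source may have more. Where it says the series, first, only, none or still open, it means among the compounds named here.

Of the compounds shown here, two have so far been measured in an ADME assay on microsomes from liver (Homo sapiens) for metabolic stability; on this read-out lower numbers stand for a shorter-lived compound and higher numbers for a longer-lived compound. Compound 1 `CC(C)C(c1ccc(-c2ccc3cccc(F)c3c2)[nH]c1=O)N1CCNC1=O` gives 1.03 h in this assay, and compound 2 `CCn1ncc2c(F)cc(-c3ccc(C(CC)(CC)c4nnc[nH]4)c(=O)[nH]3)cc21` gives 2.7 h. Of these two numbers, compound 1 holds the lower one, and the gap from compound 1 up to compound 2 lies beyond the usual scatter of this kind of measurement. Compound 2 differs from compound 1 in several places at once, so its value says nothing direct about any single change.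

Compound 3 `CC(C)C(c1cnc(N)s1)c1ccc(-c2ccc3cccc(F)c3c2)[nH]c1=O` has not yet been measured. It arises from compound 1 by one change, (2-amino-1,3-thiazol-5-yl in place of 2-oxoimidazolidin-1-yl on a saturated chain carbon bound to an aromatic carbon and a saturated chain carbon). Going by the values given here, no pair of measured compounds shows what exchanging 2-oxoimidazolidin-1-yl for 2-amino-1,3-thiazol-5-yl does to the half-life, so the direction cannot be read from the data. The expected step is therefore modest, a 1.1-fold lower number from compound 1 to compound 3 (0.06 log units; within the scatter), and is not expected to lie clearly beyond the scatter in either direction. For compound 3 a half-life of 0.9 h is estimated, with a range from 0.35 h to 2.5 h.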

Compound 3, half-life: 0.178 h
Beside the measured number, compound 3's estimate is 5.1-fold (0.70 log units) above it; measured number below the stated range.
By their numbers in this assay, from the lowest: compound 3; then compound 1; then compound 2.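

On the saturated chain carbon bound to an aromatic carbon and a saturated chain carbon, the choice of group clearly matters in this assay: 2-amino-1,3-thiazol-5-yl in place of 2-oxoimidazolidin-1-yl gives a 5.8-fold lower number from compound 1 to compound 3 (0.76 log units; beyond the scatter). Going by these compounds alone, this is the first reading of a single change, since the two earlier compounds differ in several places at once, and it shows that this position does not tolerate every five-membered ring equally, even though both groups have the same count of heavy atoms and carry no net charge. No measurement of any property accompanies this step, so the data offer no explanation for its size.

What the compounds shown leave open is whether the lower number goes with the amine or with the ring that carries it; an unsubstituted 1,3-thiazol-5-yl, or an open-chain urea in place of the 2-oxoimidazolidin-1-yl, would help to separate the two. On these data alone, it also remains open whether the same exchange would give a step of similar size on the core of compound 2.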